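Ethoxy to nitro on the benzyl ring of compound 3

The source may report more compounds than this note shows. Statements on the series, on what has been measured and on what is new or still open speak of the compounds shown alone.

Going by the values given here, in a functional assay on the whole organism for antagonist activity, with Mus musculus as the target (on this read-out lower numbers stand for an effect already at smaller amounts and higher numbers for an effect only at larger amounts of compound), compound 3 `CCOc1ccc(CN2CCC(C(=O)Nc3cc(Cl)c(N)cc3OC)CC2)cc1` gives 6.3 mg/kg, the only number among the three values shown. Compound 1 `CCCCCCN1CCC(C(=O)Nc2cc(Cl)c(N)cc2OC)CC1` gives only a limit, > 10 mg/kg, which is the limit of > 10 mg/kg in this assay, at which 1 of the 3 values shown sits. Compound 2 `COc1cc(N)c(Cl)cc1NC(=O)C1CCN(Cc2cccc(C#N)c2)CC1` gives only a limit, > 4 mg/kg, which is the limit of > 4 mg/kg in this assay, at which 1 of the 3 values shown sits. The step of an at least 1.5-fold lower number from compound 1 to compound 3 (0.20 log units; that floor lies within the scatter) is the sole readable one; a step that the two limits leave unreadable from compound 1 to compound 2 and a step that the limit leaves unreadable from compound 2 to compound 3 stay unreadable. Compound 4 `COc1cc(N)c(Cl)cc1NC(=O)C1CCN(Cc2ccc([N+](=O)[O-])cc2)CC1` differs from compound 3 by nitro in place of ethoxy on an aromatic carbon. Among the compounds with values here, no measured step alters a group at this ring position, and the unreadable step from compound 2 gives no size for a substituent on that ring, so in this assay a step of no more than the scatter is expected, in either direction, no change at the digits printed from compound 3 to compound 4 (within the scatter). Compound 4 is therefore estimated at 6.3 mg/kg, between 2 mg/kg and 20 mg/kg.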

Compound 4, dose for half-maximal effect: > 4 mg/kg
Compound 4: a limit, no number; the forecaster's own chance of this, stated with the estimate: 35%; the middle value does not contradict the limit.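

Compound 4 gives only a limit, so no new step can be read between it and compound 1, compound 2 or compound 3. The compounds shown leave open the size and direction of the change from ethoxy to nitro.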